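Notes on a bromophenyl swap from compound 3

A few compounds are considered here, and "the series" means these few. Any claim that something is new, unique, unknown or untested is made for them only; others in the source may bear on it.

Of the compounds shown here, three have been read so far in an ADME assay on L02 cells (Homo sapiens) for cytotoxicity, read by MTT assay, with a stated time of 24 h (a higher number here means a weaker inhibitor, a lower number a stronger inhibitor), on the shared core. Compound 1 (`COc1ccc(/C=C2\CN(C)C/C(=C\c3ccccc3F)C2=O)cc1OC`) gives 10500 nM and compound 2 (`COc1cc(/C=C2\CN(C)C/C(=C\c3ccc(Cl)c(Cl)c3)C2=O)cc(OC)c1`) gives 10600 nM in that read-out. Compound 3 (`COc1cc(/C=C2\CN(C)C/C(=C\c3cc(OC)c(OC)c(OC)c3)C2=O)cc(OC)c1`) stands at 14600 nM and lies within the scatter of both, so the three numbers form one group with no ranking inside it.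

Compound 4 (`COc1cc(/C=C2\CN(C)C/C(=C\c3ccc(Br)cc3)C2=O)cc(OC)c1OC`) has no number yet. Relative to compound 3, it has 4-bromophenyl in place of 3,5-dimethoxyphenyl on a double-bonded chain carbon bound to a double-bonded ring carbon.

Within the data shown here, no two measured compounds differ in one place only, so no direct step is available to size this change. Among the measured compounds shown here, the only guide is the narrow spread of the three values, which holds although their aromatic groups vary, and compounds 1 and 2 also carry halogen on one aromatic ring. No shift beyond the scatter is therefore expected in this assay and the estimated step is a 1.5-fold lower number from compound 3 to compound 4 (0.16 log units; within the scatter) in this case. With so little evidence, the range is kept wide. Compound 4 is estimated at 10000 nM with an expected range from 5000 nM to 20000 nM in this series.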

Compound 4, half-maximal inhibitory concentration: 15400 nM
For compound 4 the middle estimate is 1.5-fold (0.19 log units) below the measured one; measured number inside the range.
By their numbers in this assay, from the lowest: compounds 1, 2, 3 and 4 (each within the scatter of the next).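

In this assay, a 1.1-fold higher number from compound 3 to compound 4 (0.02 log units; within the scatter) gives the series its first direct reading of a single change, 4-bromophenyl in place of 3,5-dimethoxyphenyl on a double-bonded chain carbon bound to a double-bonded ring carbon. Until now, the closeness of the numbers could only be seen across compounds that differ in more than one place, whereas here the two readings cannot be told apart with everything else on the shared core held constant. At this place, then, a carbon-only aromatic ring bearing bromine and no hydrogen-bond acceptors reads the same within the scatter as the 3,5-dimethoxyphenyl group, and no measurement available here accounts for that result.

This is one step on the background of compound 3, so it cannot show whether the same holds when the other aromatic group on the shared core is different. Also open, on these data alone, is whether a group of another kind at this place, such as a phenyl ring carrying a carboxylic acid or an amine, would stay within the scatter of compound 3 in this assay.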